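Notes on the step to compound 4

The source may report more compounds than this note shows. Statements on the series, on what has been measured and on what is new or still open speak of the compounds shown alone.

Of the compounds shown here, three have been measured in a physicochemical assay for lipophilicity, at pH 7.4; on this read-out lower numbers stand for lower lipophilicity and higher numbers for higher lipophilicity. Compound 1 (`Cc1cc(N[C@H](CCCCN)C(=O)NO)cc(C)c1F`) gives < 3 as a limit and not a number. Compound 2 (`Cc1cc(S(=O)(=O)NCCCC[C@@H](Nc2cc(C)c(F)c(C)c2)C(=O)NO)ccc1F`) gives < 3 as a limit as well. Compound 3 (`Cc1cc(N[C@H](CCCCNCc2cccc(F)c2)C(=O)NO)cc(C)c1F`) gives < 3 as a limit too, so its standing is fixed by no number.

Compound 4 (`Cc1cc(N[C@H](CCCCNCc2ccc(C(C)(C)C)cc2)C(=O)NO)cc(C)c1F`) has not yet been measured. It carries 4-(tert-butyl)phenyl in place of 3-fluorophenyl on a saturated chain carbon bound to an amine nitrogen.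

Among the measured compounds shown here, the one measured step that bears on this change is a step that the two limits leave unreadable from compound 1 to compound 3 and it gives no size to carry over. For the measured compounds named here, the series so far offers only the limit of < 3 in this assay, at which 3 of the 3 values shown sit, as its evidence. The expectation therefore rests on the structural change alone. A modest step upward in this assay is expected, and the measurement may again return only a limit. The estimate amounts to a step that the limit leaves unreadable from compound 3 to compound 4 as an expected step of uncertain size. For compound 4 the estimated value is 2.8 with an expected range from 2.2 to 3.4 on this reading.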

Compound 4, distribution coefficient: < 3
Compound 4: only a limit was reported (the forecaster's own chance of this, stated with the estimate: 60%); the middle value lies beyond the limit too.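

In this assay compound 4 gives < 3 as a limit and not a number. Among the compounds shown here, compound 3 also rests on a limit, so no step between compound 3 and compound 4 can be read. The compounds shown leave open the actual value of every compound in this assay and with it the size of any step: the limit of < 3 in this assay, at which 4 of the 4 values shown sit.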